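The source may hold more compounds than are shown below. What is called first, only, known or untested is meant among the compounds shown, and "the series" means these compounds.

Measured in a functional assay on HL-60 cells (Homo sapiens) for cytotoxicity, read by CCK-8 assay, with a stated time of 24 h; on this read-out lower numbers stand for stronger inhibition and higher numbers for weaker inhibition:
Compound 1 `C=CC(=O)N1C(=O)CC(c2ccc(C(F)(F)F)cc2)Sc2ccccc21`: 106000 nM
Compound 2 `C=CC(=O)N1C(=O)CC(c2cccs2)Sc2ccccc21`: 695000 nM
Compound 3 `C=CC(=O)N1C(=O)CC(c2ccccc2C(F)(F)F)Sc2ccccc21`: 96400 nM

The three compounds share a core and an acrylamide-type side chain, and they fall into two groups on the numbers. Compound 1, at 106000 nM, and compound 3, at 96400 nM, lie within the usual scatter of each other. Compound 2, at 695000 nM, stands apart at the high end, with a number beyond the scatter from both of the others. All three numbers therefore point to weak inhibition in this assay.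

The next compound to be tested is compound 4 `C=CC(=O)N1C(=O)CC(c2ccc(-c3ccccc3)cc2)Sc2ccccc21`, which has phenyl in place of trifluoromethyl on an aromatic carbon, para to a large group (phenyl in place of trifluoromethyl on an aromatic carbon). Among the compounds with values here, no pair of measured compounds differs in one place, so the data offer no direct precedent for this change. No step beyond the scatter is expected, and the estimate stays close to compound 1 at 106000 nM. The expected step is a 1.2-fold lower number from compound 1 to compound 4 (0.10 log units; within the scatter). The range is kept wide, as compound 2 at 695000 nM shows how far a number in this small set can lie from the others. For compound 4 the estimated value is 85000 nM, with an expected range from 30000 nM to 240000 nM.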

Compound 4, half-maximal inhibitory concentration: 118000 nM
The estimate for compound 4 lay 1.4-fold (0.14 log units) below the measured number, within the range that was stated.
By their numbers in this assay, from the lowest: compounds 3, 1 and 4 (each within the scatter of the next); then compound 2.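

In this assay, within the data shown here, phenyl in place of trifluoromethyl on an aromatic carbon, para to a large group, gives a 1.1-fold higher number from compound 1 to compound 4 (0.05 log units; within the scatter) and so provides the first comparison in this set between compounds that differ in one place. For this pair, a phenyl group, with its six heavy atoms and six-membered aromatic ring of carbon only, can stand where trifluoromethyl, with four heavy atoms and no ring, stood without a change in the number beyond the scatter, although this single pair shows no general rule for the position. Nothing measured here gives a reason for this result.

The compounds shown leave open whether an amine, a carboxylic acid or a methoxy group at this same place would give a step beyond the scatter from compound 1, since both groups compared so far carry no hydrogen-bond donors or acceptors. They also leave open whether the same exchange of trifluoromethyl for phenyl, made on compound 3, would give a step of similar size.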